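Removing the hydroxy from compound 1

The source may report more compounds than this note shows. Statements on the series, on what has been measured and on what is new or still open speak of the compounds shown alone.

Compound 1 `Cn1c(=O)c(=O)n(C2CCCC2)c2nc(N/N=C/c3cc(C(F)(F)F)c(O)c(C(F)(F)F)c3)ncc21` gives 27100 nM
Compound 2 `Cn1c(=O)c(=O)n(C2CCCC2)c2nc(N/N=C/c3ccc(F)cc3Cl)ncc21` gives 13800 nM
Compound 3 `COc1ccc(/C=N/Nc2ncc3c(n2)n(C2CCCC2)c(=O)c(=O)n3C)c(OC)c1` gives > 100000 nM as a limit of the assay

In a functional assay on HCT-116 cells (Homo sapiens) for antiproliferative activity, read by MTT assay (a higher number here means a weaker inhibitor, a lower number a stronger inhibitor), compound 1 gives 27100 nM and lies within the scatter of compound 2 at 13800 nM among the numbers available. Compound 4 `Cn1c(=O)c(=O)n(C2CCCC2)c2nc(N/N=C/c3cc(C(F)(F)F)cc(C(F)(F)F)c3)ncc21` differs from compound 1 by hydrogen in place of hydroxy on an aromatic carbon, ortho to two trifluoromethyl groups hydrogen in place of hydroxy on an aromatic carbon and para to a large group. Within the data shown here, the only measured step, an at least 7.2-fold higher number from compound 2 to compound 3 (0.86 log units; beyond the scatter), bears on this indirectly. It shows that a change of groups on this aromatic ring can move the number beyond the scatter, but it removes no hydroxy. Among the measured compounds shown here, no measured step therefore sets a size or direction for this change, and the expectation stays close to compound 1 at 27100 nM with a wide margin. The expected step in this assay is a 1.1-fold lower number from compound 1 to compound 4 (0.04 log units; within the scatter) and no shift beyond the scatter is anticipated. Compound 4 is estimated at 25000 nM (expected range from 8000 nM to 85000 nM).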

Compound 4, half-maximal inhibitory concentration: 4360 nM
Estimate against measurement, compound 4: 5.7-fold (0.76 log units) above; measured number below the stated range.
By their numbers in this assay, from the lowest: compound 4; then compounds 2 and 1 (each within the scatter of the next). At a limit, above all of these: compound 3.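

In this assay, the hydroxy on this aromatic carbon, ortho to two trifluoromethyl groups and para to a large group, proves to be a position that counts on its own: hydrogen in its place gives a 6.2-fold lower number from compound 1 to compound 4 (0.79 log units; beyond the scatter). Among these compounds, the earlier compounds showed only that changing several groups on this ring can move the number, whereas this step isolates a single group and gives the change a direction, with the lower number on the side without the hydroxy. Nothing reported here accounts for the size of this step.

The compounds shown leave open how an amine, a methoxy or a carboxylic acid on this carbon would compare with hydroxy and hydrogen. They also leave open whether removing the hydroxy would give a similar step on a ring without the two trifluoromethyl groups.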